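The compounds below may be only part of what the source reports. "The series", "measured", "known", "first", "only" and "open" are said of these compounds alone.

- compound 1 `COc1cc(C2Oc3cc([C@H]4Oc5cc(O)cc(O)c5C(=O)[C@@H]4O)ccc3OC2COC(=O)c2ccccc2)ccc1O` gives 12700 nM
- compound 2 `COc1cc(C2Oc3cc([C@H]4Oc5cc(O)cc(O)c5C(=O)[C@@H]4O)ccc3OC2COC(=O)c2cc([N+](=O)[O-])cc([N+](=O)[O-])c2)ccc1O` gives 14600 nM
- compound 3 `COc1cc(C2Oc3cc([C@H]4Oc5cc(O)cc(O)c5C(=O)[C@@H]4O)ccc3OC2COC(=O)c2cc(N)cc([N+](=O)[O-])c2)ccc1O` has no measurement yet

In a functional assay on liver (Rattus norvegicus, strain Sprague-Dawley) for inhibition, with a stated time of 1 h (on this read-out higher numbers stand for weaker inhibition and lower numbers for stronger inhibition), compound 1 gives 12700 nM and compound 2 gives 14600 nM and these two numbers, the only ones available, lie within the scatter of each other.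

The change from compound 2 to compound 3 is amino in place of nitro on an aromatic carbon and in words it is amino in place of nitro on an aromatic carbon, meta to a nitro group, turning 3,5-dinitrophenyl into 3-amino-5-nitrophenyl.

Within the data shown here, one measured step bears on this ring: 3,5-dinitrophenyl in place of phenyl on a carbonyl carbon, a 1.1-fold higher number from compound 1 to compound 2 (0.06 log units; within the scatter) and so within the scatter. Among the measured compounds shown here, no measured compound carries an amino group, which leaves the evidence thin. On this single step, no change beyond the scatter is expected in this assay for the new exchange.

The expected change is a 1.1-fold lower number from compound 2 to compound 3 (0.03 log units; within the scatter) and this estimate lies within the scatter.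

For compound 3 the estimated value is 13500 nM with an expected range from 7000 nM to 27000 nM as its limits.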

Compound 3, half-maximal inhibitory concentration: 200 nM
Compound 3: the middle estimate sits 68-fold (1.83 log units) above what was measured; the measured number lies below the stated range.
By their numbers in this assay, from the lowest: compound 3; then compounds 1 and 2 (each within the scatter of the next).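

In this assay, this ring position turns out to be sensitive to its substituent: amino in place of nitro, meta to a nitro group, gives a 73-fold lower number from compound 2 to compound 3 (1.86 log units; beyond the scatter), and 3-amino-5-nitrophenyl in place of phenyl on the carbonyl carbon gives a 64-fold lower number from compound 1 to compound 3 (1.80 log units; beyond the scatter). The earlier pair gave no sign of this, with 3,5-dinitrophenyl in place of phenyl giving only a 1.1-fold higher number from compound 1 to compound 2 (0.06 log units; within the scatter), which lies within the scatter; substitution on this ring therefore does not by itself shift the number, and among the three compounds only the 3-amino-5-nitrophenyl ester stands apart. Nothing at hand accounts for the size of this step, and its cause remains unassigned.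

As far as these compounds go, it remains open whether the amino group is sufficient alone or only acts together with the remaining nitro group, a question that 3-aminophenyl and 3,5-diaminophenyl groups on the same carbonyl would separate. From the compounds shown here alone, it is equally open whether the hydrogens on that nitrogen matter, which a dimethylamino group or an acetamide in the same place would test.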